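Oxygen-Bearing Phenyl Replaces Dichlorophenyl in Compound 4

The source may hold more compounds than are shown below. What is called first, only, known or untested is meant among the compounds shown, and "the series" means these compounds.

Compound 3 `CN(C)CCn1cnnc1-c1cc(Oc2ccc(NC(=O)N/N=C/c3cccc(Cl)c3Cl)cc2F)ccn1` gives the lowest number of the three measured compounds in a functional assay on NCI-H460 cells (Homo sapiens) for cytotoxicity, read by MTT assay, with a stated time of 72 h (on this read-out lower numbers stand for stronger inhibition and higher numbers for weaker inhibition), at 72 nM. Compound 1 `CN(C)CCn1cnnc1-c1cc(Oc2ccc(NC(=O)N/N=C/c3c(Cl)cccc3Cl)cc2F)ccn1` gives 350 nM in this assay, and compound 2 `COc1ccc(/C=N/NC(=O)Nc2ccc(Oc3ccnc(-c4nncn4CCN(C)C)c3)c(F)c2)c(OC)c1` gives 1570 nM in this assay. Compound 4 `COc1ccc(/C=N/NC(=O)Nc2ccc(Oc3ccnc(-c4nncn4CCN(C)C)c3)c(F)c2)cc1O` differs from compound 3 in one place: 3-hydroxy-4-methoxyphenyl in place of 2,3-dichlorophenyl on a carbon with a double bond to nitrogen. Among the compounds with values here, two measured steps bear on this change. Moving from a dichlorophenyl to a dimethoxyphenyl on that carbon gave a 4.5-fold higher number from compound 1 to compound 2 (0.65 log units; beyond the scatter), and the reverse kind of change gave a 22-fold lower number from compound 2 to compound 3 (1.34 log units; beyond the scatter). The group entering in compound 4 carries oxygen substituents, as the ring of compound 2 does, so in this assay a step to a clearly higher number is expected for compound 4, a 15-fold higher number from compound 3 to compound 4 (1.18 log units; beyond the scatter). Within the data shown here, only one oxygen-bearing ring has been measured, and its hydroxyl is new, so the exact size of the step is uncertain. Compound 4 is therefore estimated at 1100 nM in this assay, with a range from 300 nM to 4000 nM.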

Compound 4, half-maximal inhibitory concentration: 620 nM
Beside the measured number, compound 4's estimate is 1.8-fold (0.25 log units) above it, and the stated range covers the measured number.
By their numbers in this assay, from the lowest: compound 3; then compounds 1 and 4 (each within the scatter of the next); then compound 2.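

In this assay, a second oxygen-bearing ring also gives up much of what the 2,3-dichlorophenyl group provides, with an 8.6-fold higher number from compound 3 to compound 4 (0.94 log units; beyond the scatter). The two oxygen-bearing rings are not interchangeable, since 3-hydroxy-4-methoxyphenyl in place of 2,4-dimethoxyphenyl gives a 2.5-fold lower number from compound 2 to compound 4 (0.40 log units; beyond the scatter), so the kind and placing of the oxygen groups count, not merely their presence. Against the 2,6-dichlorophenyl group there is a 1.8-fold higher number from compound 1 to compound 4 (0.25 log units; within the scatter), so a dichlorophenyl group does not always separate from an oxygen-bearing ring here, and only the 2,3-dichlorophenyl group of compound 3 does so in all comparisons.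

No measurement at hand explains these differences. On these data alone, whether the hydroxyl itself matters remains open, and a ring carrying an amine or a carboxylic acid in its place would test this.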